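Enlarging the Aryl Group on the Ring Nitrogen

The source may hold more compounds than are shown below. What is called first, only, known or untested is meant among the compounds shown, and "the series" means these compounds.

Compound 1 `CC(C)[C@@H]1CC[C@@H](C)C[C@@]12N(C)C(=O)[C@@H]1[C@H]3C(=O)NC(=O)[C@H]3ON12` carries a hydrogen on an amide-type nitrogen in a ring of the shared core; in a functional assay, read by spectrophotometry, with a stated time of 2 h, tested at 2.5 mg/mL (a higher number here means a stronger effect of the compound at the concentration tested, a lower number a weaker effect), compound 1 gives 38%. Compound 2 `CC(C)[C@@H]1CC[C@@H](C)C[C@@]12N(C)C(=O)[C@@H]1[C@H]3C(=O)N(c4ccc(Cl)cc4)C(=O)[C@H]3ON12` gives 61.3%, and compound 3 `COc1ccc(N2C(=O)[C@H]3[C@H](ON4[C@@H]3C(=O)N(C)[C@@]43C[C@H](C)CC[C@H]3C(C)C)C2=O)cc1` gives 59.3%. Compound 3 stands second of the three numbers, close to compound 2 and well clear of compound 1. Compound 4 `CC(C)[C@@H]1CC[C@@H](C)C[C@@]12N(C)C(=O)[C@@H]1[C@H]3C(=O)N(c4ccc5ccccc5c4)C(=O)[C@H]3ON12` differs from compound 3 by naphthalen-2-yl in place of 4-methoxyphenyl on an amide-type nitrogen in a ring. Among the compounds with values here, the steps that bear on it are a number 23.3 percentage points higher from compound 1 to compound 2 (beyond the scatter) and a number 21.3 percentage points higher from compound 1 to compound 3 (beyond the scatter), both modest gains for an aromatic group in place of hydrogen on that nitrogen, while a number 2 percentage points lower from compound 2 to compound 3 (within the scatter) shows the two aromatic groups alike. Within the data shown here, no measured compound carries naphthalen-2-yl. Compound 4 is therefore expected to move by a number 0.7 percentage points higher from compound 3 to compound 4 (within the scatter), a step within the scatter. Compound 4 is estimated at 60%, between 45% and 75%.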

Compound 4, a percentage reported as activity, at one concentration (the size of the read-out at that concentration, not a potency): 45.1%
Compound 4: the middle estimate sits 14.9 percentage points above what was measured; measured number inside the range.
By their numbers in this assay, from the lowest: compounds 1 and 4 (each within the scatter of the next); then compounds 3 and 2 (each within the scatter of the next).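

In this assay, not every aromatic group on this ring nitrogen keeps the gain over hydrogen: naphthalen-2-yl, with its two six-membered aromatic rings, gives a number 14.2 percentage points lower from compound 3 to compound 4 (beyond the scatter) and a number 16.2 percentage points lower from compound 2 to compound 4 (beyond the scatter). Against the parent with hydrogen on that nitrogen, it gives a number 7.1 percentage points higher from compound 1 to compound 4 (within the scatter), so the gain seen with 4-chlorophenyl and 4-methoxyphenyl does not carry over to this group. No measurement shown here explains the difference. Going by these compounds, how an unsubstituted phenyl, naphthalen-1-yl, cyclohexyl or an aminoethyl chain on this nitrogen would compare remains open.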